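Benzoyl to carboxy: working notes on compound 3

A few compounds are considered here, and "the series" means these few. Any claim that something is new, unique, unknown or untested is made for them only; others in the source may bear on it.

In an ADME assay on HEK293 cells (Homo sapiens) for cytotoxicity, with a stated time of 72 h (on this read-out higher numbers stand for an effect only at larger amounts of compound and lower numbers for an effect already at smaller amounts), compound 1 `C=C[C@@](C)(/C=C/c1ccc(OS(=O)(=O)c2ccc(C)cc2)cc1)CCC=C(C)C` gives > 36600 nM as a limit. Compound 2 `C=C[C@@](C)(/C=C/c1ccc(O)c(/C=C/C(=O)c2ccccc2)c1)CCC=C(C)C` also gives only a limit, > 7410 nM in this read-out, so neither shown value is a number. Compound 3 `C=C[C@@](C)(/C=C/c1ccc(O)c(/C=C/C(=O)O)c1)CCC=C(C)C` differs from compound 2 by benzoyl to carboxy, hydroxy in place of phenyl on a carbonyl carbon on the shared core. For the measured compounds named here, no measured step bears on this change. The expected move is toward higher numbers, with an estimated size of a step that the limit leaves unreadable from compound 2 to compound 3 and low confidence. Compound 3 is expected near 30000 nM within a range of 8000 nM to 100000 nM in this assay and may again report only as a limit.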

Compound 3, half-maximal effective concentration: > 36600 nM
Compound 3 ended at the assay's limit; the forecaster's own chance of this, stated with the estimate: 70%; middle value at least 1.2-fold (0.08 log units) away from the limit.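

For the compounds shown here, compound 2 and compound 3 both stand only as limits, and no step between them can be read. On these data alone, whether benzoyl to carboxy moves this read-out at all, and in which direction, stays open.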